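Swapping Methoxyphenyl for Difluorophenyl in a Receptor Agonist Series

The source may hold more compounds than are shown below. What is called first, only, known or untested is meant among the compounds shown, and "the series" means these compounds.

compound 1: `COc1cccc(Cc2cnc(CCc3ccc(-c4ccccc4C(=O)O)cc3)[nH]2)c1` — 4120 nM
compound 2: `CCCCc1cnc(C(CCCC)Cc2ccc(-c3ccccc3C(=O)O)cc2)[nH]1` — 2660 nM

Both numbers come from an in vitro functional assay on cells for agonist activity at Bombesin receptor subtype-3 (Homo sapiens), read by luminescence and calcium flux; a lower number here means that less compound is needed, a higher number that more compound is needed for the effect. Compound 1 has the higher of the two numbers, but the gap to compound 2 lies within the scatter, so the two cannot be ordered. Compound 3 `O=C(O)c1ccccc1-c1ccc(CCc2ncc(Cc3cccc(F)c3F)[nH]2)cc1` differs from compound 1 in one place: 2,3-difluorophenyl in place of 3-methoxyphenyl on a saturated chain carbon bound to an aromatic carbon. Among the compounds with values here, no measured pair shows this change, so its size is unknown; the expectation is a step from compound 1 to compound 3 of a 1.4-fold lower number from compound 1 to compound 3 (0.14 log units; within the scatter), within the scatter and in no firm direction. Compound 3 is therefore estimated at 3000 nM, with a range from 1000 nM to 10000 nM.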

Compound 3, half-maximal effective concentration: 87 nM
For compound 3 the middle estimate is 34-fold (1.54 log units) above the measured one; the measured number lies below the stated range.
By their numbers in this assay, from the lowest: compound 3; then compounds 2 and 1 (each within the scatter of the next).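

In this assay, this position proves far from neutral: 2,3-difluorophenyl in place of 3-methoxyphenyl gives a 47-fold lower number from compound 1 to compound 3 (1.68 log units; beyond the scatter). The two groups match in heavy-atom count and each holds one six-membered aromatic ring, so a large step can arise even when those counts stay the same. Nothing available here explains the step.

From the compounds shown here alone, whether it comes from losing the methoxy group, gaining the fluorines, or both remains open. Plain phenyl or 3-fluorophenyl at this place would help separate these possibilities.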